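This account rests on a few compounds, and the source may have more. Where it says the series, first, only, none or still open, it means among the compounds named here.

Working notes on the series.

The shared core is carried by compound 1 `Cc1cccc(N2CCN(C(=O)CN3C(=O)CC(C)(c4ccccc4)C3=O)CC2)c1`, which in a functional assay on the whole organism (strain CD-1) with Mus musculus as the target, in the maximal electroshock model, with a stated time of 0.5 h (a lower number here means that less compound is needed, a higher number that more compound is needed for the effect), gives 100 mg/kg. On the two numbers reported so far compound 1 stands lowest. Among the measured compounds shown here, its nearest neighbour is compound 2 `CC1(c2ccccc2)CC(=O)N(CC(=O)N2CCN(c3cccc(Cl)c3)CC2)C1=O`, which in this assay gives 300 mg/kg; the step of a 3.0-fold higher number from compound 1 to compound 2 (0.48 log units; beyond the scatter) is the only measured step and it rests on a chloro in place of methyl on an aromatic carbon. Compound 3 `CC1(c2ccccc2)CC(=O)N(CC(=O)N2CCN(c3cccc(Cl)c3Cl)CC2)C1=O` carries a second chloro on the same aromatic ring and in this assay is reported as "not active" (no number reported), so no number stands for it.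

Compound 4 `CC1(c2ccccc2)CC(=O)N(CC(=O)N2CCN(c3ncccn3)CC2)C1=O` differs from compound 1 by pyrimidin-2-yl in place of 3-methylphenyl on an amine nitrogen in a ring. For the measured compounds named here, no measured step bears on this exchange of the whole aryl group for a heteroaryl group; the one step in hand, from methyl to chloro, concerns a substituent on the ring and not the ring itself. What the series shows is that every change made on this aryl group so far has raised the number or removed activity. For compound 4 a step of a 2.0-fold higher number from compound 1 to compound 4 (0.30 log units; within the scatter) in this assay is therefore expected, upward and beyond the scatter, with a real chance that no number is obtained. The estimate for compound 4 in this assay is 200 mg/kg, expected to lie between 70 mg/kg and 500 mg/kg.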

Compound 4, minimum effective dose: "not active" (no number reported)
No number was reported for compound 4, so the estimate cannot be set against anything.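

Among the compounds shown here, compound 4, like compound 3, has no number in this assay, so no new step from compound 1 or any other compound can be read. Nothing measured here accounts for this result. The compounds shown leave open whether any heteroaryl group in place of 3-methylphenyl on the ring nitrogen can give a number in this assay at all.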